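Aryl substituent change on the shared core: fluoro, bromo, methoxy

This account rests on a few compounds, and the source may have more. Where it says the series, first, only, none or still open, it means among the compounds named here.

Measured so far:
Compound 1 `CCCNC(=O)c1cc(Oc2ccc(NC(=O)c3cc4cccnc4n(-c4ccc(F)cc4)c3=O)cc2)ccn1` gives 960 nM in a functional assay on U-87MG ATCC cells for antiproliferative activity against U-87 MG (Homo sapiens), read by MTT assay, with a stated time of 72 h; on this read-out lower numbers stand for stronger inhibition and higher numbers for weaker inhibition
Compound 2 `CCCNC(=O)c1cc(Oc2ccc(NC(=O)c3cc4cccnc4n(-c4ccc(Br)cc4)c3=O)cc2)ccn1` gives 5190 nM in this assay

Going by the values given here, compound 2 stands at the higher of the two numbers so far in this assay; the one measured step, a 5.4-fold higher number from compound 1 to compound 2 (0.73 log units; beyond the scatter), is the only comparison available. Compound 3 `CCCNC(=O)c1cc(Oc2ccc(NC(=O)c3cc4cccnc4n(-c4ccc(OC)cc4)c3=O)cc2)ccn1` differs from compound 2 by methoxy in place of bromo on an aromatic carbon. Among the compounds with values here, no measured compound carries a methoxy group, so the only step that bears on this change is a 5.4-fold higher number from compound 1 to compound 2 (0.73 log units; beyond the scatter), which shows that swapping the group at this place on the ring moves the number by more than the usual scatter. Methoxy is neither of the two halogens measured, so the direction of the step from compound 2 is uncertain, and the expectation is a number somewhere between those of compound 1 and compound 2, with a wide range to cover either outcome. For compound 3 the estimate in this assay is 2500 nM (range 800 nM to 8000 nM), which corresponds to an expected step of a 2.1-fold lower number from compound 2 to compound 3 (0.32 log units; beyond the scatter).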

Compound 3, half-maximal inhibitory concentration: 8210 nM
Compound 3: middle estimate off by 3.3-fold (0.52 log units), on the low side; the whole stated range lies below it.
By their numbers in this assay, from the lowest: compound 1; then compounds 2 and 3 (each within the scatter of the next).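

In this assay, the change from 4-bromophenyl to 4-methoxyphenyl gives a 1.6-fold higher number from compound 2 to compound 3 (0.20 log units; within the scatter) and so does not separate the two groups, even though methoxy brings one hydrogen-bond acceptor by count and bromo none. Fluoro now stands apart from two different groups at this place: an 8.6-fold higher number from compound 1 to compound 3 (0.93 log units; beyond the scatter) joins the earlier 5.4-fold higher number from compound 1 to compound 2 (0.73 log units; beyond the scatter), so among these three compounds the lowest number belongs to compound 1, while compound 2 and compound 3 form one level within the scatter. The result therefore points to something particular to the fluoro compound rather than a graded order across the three groups, but no measurement in hand accounts for this.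

On these data alone, it remains open whether a chloro group, a hydroxyl group or an amine at this place would fall with compound 1 or with compound 2 and compound 3. As far as these compounds go, it is also open whether the separation of fluoro from bromo and methoxy would persist if another part of the shared core were changed.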